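From phenyl to 5-methylthiophen-2-yl in compound 4

This account rests on a few compounds, and the source may have more. Where it says the series, first, only, none or still open, it means among the compounds named here.

- compound 1 `CCOc1cc(NC(=O)CCCCCC(=O)Nc2cc(-c3ccccc3)ccc2N)cc2c1OCC([N+](=O)[O-])=C2` - 7030 nM
- compound 2 `CCOc1cc(NC(=O)CCCCC(=O)Nc2cc(-c3ccccc3)ccc2N)cc2c1OCC([N+](=O)[O-])=C2` - 19900 nM
- compound 3 `CCOc1cc(NC(=O)CCCCCCC(=O)Nc2cc(-c3ccc(C)s3)ccc2N)cc2c1OCC([N+](=O)[O-])=C2` - 5330 nM

In a functional assay on MCF7 cells (Homo sapiens) for antiproliferative activity, read by MTT assay, with a stated time of 48 h (on this read-out higher numbers stand for weaker inhibition of growth and lower numbers for stronger inhibition of growth), compound 1 gives 7030 nM and lies within the scatter of compound 3, while compound 2 stands clearly higher. Compound 4 `CCOc1cc(NC(=O)CCCCCC(=O)Nc2cc(-c3ccc(C)s3)ccc2N)cc2c1OCC([N+](=O)[O-])=C2` keeps the chain and core of compound 1 and differs in one place, with 5-methylthiophen-2-yl in place of phenyl on an aromatic carbon. For the measured compounds named here, no measured pair shows this swap alone. Compound 3 carries the same group on a different chain and gives 5330 nM in this assay, so no step beyond the scatter is expected. The estimated change (a 1.2-fold lower number from compound 1 to compound 4 (0.07 log units; within the scatter)) is small. For compound 4 the expected value is 6000 nM (estimated range 2500 nM to 14000 nM).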

Compound 4, concentration for 50% growth inhibition: > 20000 nM
Compound 4: a limit, no number; the forecaster's own chance of this, stated with the estimate: 3%; middle value at least 3.3-fold (0.52 log units) away from the limit.
By their numbers in this assay, from the lowest: compounds 3 and 1 (each within the scatter of the next); then compound 2. At a limit, above all of these: compound 4.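

In this assay, putting 5-methylthiophen-2-yl in place of phenyl on this aromatic carbon, with chain and core unchanged, gives an at least 2.8-fold higher number from compound 1 to compound 4 (0.45 log units; beyond the scatter). Compound 4 stands at a limit of the assay, not at a number: the limit of > 20000 nM in this assay, at which 1 of the 4 values shown sits. The ring at this position therefore matters on this chain, and compound 3, with the same group on a different chain, was no guide to it.

From the compounds shown here alone, how far compound 4 lies past its limit stays open. So does whether a plain thiophen-2-yl or a pyridine ring here would track phenyl or 5-methylthiophen-2-yl.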